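Moving the nitro group: 2-nitrophenyl to 4-nitrophenyl

A few compounds are considered here, and "the series" means these few. Any claim that something is new, unique, unknown or untested is made for them only; others in the source may bear on it.

All readings come from a functional assay on NCI-H460 cells (Homo sapiens) for cytotoxicity, read by sulforhodamine B assay; on this read-out lower numbers stand for stronger inhibition of growth and higher numbers for weaker inhibition of growth. Compound 1 `CC1=CC[C@@H]([C@@](C)(O)CCCC(C)(C)NC(=S)N/N=C\c2ccccc2)CC1` gives > 100000 nM, which is a limit of the assay and not a number. Compound 2 `CC1=CC[C@@H]([C@@](C)(O)CCCC(C)(C)NC(=S)N/N=C\c2ccc(O)cc2)CC1` gives a true number, 20700 nM. Compound 3 `CC1=CC[C@@H]([C@@](C)(O)CCCC(C)(C)NC(=S)N/N=C\c2ccccc2[N+](=O)[O-])CC1` gives > 100000 nM, again only a limit. Compound 3 therefore sits at the limit of > 100000 nM in this assay, at which 2 of the 3 values shown sit.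

The next structure is compound 4 `CC1=CC[C@@H]([C@@](C)(O)CCCC(C)(C)NC(=S)N/N=C\c2ccc([N+](=O)[O-])cc2)CC1`. The change is 4-nitrophenyl in place of 2-nitrophenyl on a carbon with a double bond to nitrogen.

Within the data shown here, two measured steps bear on it. Hydroxy in place of hydrogen on an aromatic carbon gave an at least 4.8-fold lower number from compound 1 to compound 2 (0.68 log units; beyond the scatter). Nitro in place of hydrogen on an aromatic carbon gave a step that the two limits leave unreadable from compound 1 to compound 3. The 4-hydroxyphenyl group of compound 2 is thus the only one so far to give a number, and it is not a nitro group. A modest step to a lower number is expected in this assay, with a reading that stays at the limit about equally likely. The estimated step is an at least 1.6-fold lower number from compound 3 to compound 4 (0.22 log units; that floor lies within the scatter). For compound 4 the expected value is 60000 nM, with an estimated range of 20000 nM to 100000 nM.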

Compound 4, concentration for total growth inhibition: > 100000 nM
Compound 4: only a limit was reported; the forecaster's own chance of this, stated with the estimate: 50%; middle value at least 1.6-fold (0.22 log units) away from the limit.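

In this assay compound 4 gives > 100000 nM, which is a limit of the assay and not a number. The steps to compound 4 from compound 1 and from compound 3 cannot be read, as both ends of each are limits, so 4-nitrophenyl in place of 2-nitrophenyl brings no number and the series stays crowded at one ceiling: the limit of > 100000 nM in this assay, at which 3 of the 4 values shown sit. The comparison with compound 2 now sets nitro and hydroxy on the same phenyl pattern, and nitro in place of hydroxy gives an at least 4.8-fold higher number from compound 2 to compound 4 (0.68 log units; beyond the scatter), leaving 4-hydroxyphenyl as the only group shown with a number.

Going by these compounds, how far compound 1, compound 3 and compound 4 differ from one another past the limit stays open. Also open, on these data alone, is whether a number appears only with hydroxy, or also with 4-aminophenyl or 4-methoxyphenyl.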